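The compounds below may be only part of what the source reports. "The series", "measured", "known", "first", "only" and "open" are said of these compounds alone.

Two compounds sharing a central ring with two double-bonded arms have been tested in a functional assay on HT-1080 cells (Homo sapiens) for cytotoxicity, read by MTT assay, with a stated time of 72 h; a higher number here means a weaker inhibitor, a lower number a stronger inhibitor. Compound 1, `COc1cccc(/C=C2\CCC/C(=C\c3cccc(Cl)c3)C2=O)c1OC`, gives 10300 nM. Compound 2, `COc1ccc(/C=C2\CCC/C(=C\c3ccccc3Cl)C2=O)cc1OC`, gives 6800 nM. These two numbers lie within the usual scatter of each other, so on the numbers shown compound 2 does not stand apart from compound 1; the pair shows only that both compounds are weak inhibitors in this assay.

Compound 3, `COc1ccc(/C=C2\CCC/C(=C\c3ccc(O)cc3)C2=O)cc1OC`, has not yet been measured. It differs from compound 2 in one place: 4-hydroxyphenyl in place of 2-chlorophenyl on a double-bonded chain carbon bound to a double-bonded ring carbon. No measured step of this kind exists here, so the direction of the change cannot be read from the numbers shown. The expectation is a step of a 1.2-fold higher number from compound 2 to compound 3 (0.07 log units; within the scatter), that is, no change beyond the scatter. On that basis compound 3 is estimated at 8000 nM in this assay, with a likely range from 3000 nM to 25000 nM.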

Compound 3, half-maximal inhibitory concentration: 16800 nM
Compound 3: middle estimate off by 2.1-fold (0.32 log units), on the low side; the range from low to high includes it.
By their numbers in this assay, from the lowest: compounds 2, 1 and 3 (each within the scatter of the next, the first and the last beyond it).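

Among these compounds, on the double-bonded chain carbon bound to a double-bonded ring carbon, replacing 2-chlorophenyl with 4-hydroxyphenyl gives a 2.5-fold higher number from compound 2 to compound 3 (0.39 log units; beyond the scatter) in this assay and so provides the first single-place step here that lies beyond the scatter. What sits at this position can therefore shift the result, even though the two groups have the same heavy-atom count and one aromatic ring each, and only the entering group has a hydrogen-bond donor and acceptor. The data offer no measured explanation for the step.

As far as these compounds go, whether the step comes from losing the chlorine, gaining the hydroxyl or the different numbered place on the phenyl ring remains open, as all three change at once. From the compounds shown here alone, how an amine or a carboxylic acid would behave at this position in this assay also remains unknown.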